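The source may report more compounds than this note shows. Statements on the series, on what has been measured and on what is new or still open speak of the compounds shown alone.

Among the compounds with values here, compound 2 `COc1cc(/C=C2\CN(C)C/C(=C\c3ccccc3F)C2=O)cc(OC)c1OC` is one of two compounds measured in an ADME assay on L02 cells (Homo sapiens) for cytotoxicity, read by MTT assay, with a stated time of 24 h; a higher number here means a weaker inhibitor, a lower number a stronger inhibitor. In this assay compound 2 gives 12100 nM, while compound 1 `COc1cc(/C=C2\CN(C)C/C(=C\c3ccccc3F)C2=O)cc(OC)c1` gives 11900 nM; the step of a 1.0-fold higher number from compound 1 to compound 2 (0.01 log units; within the scatter) separates them. Compound 3 `COc1cc(/C=C2\CN(C)C/C(=C\c3ccc(F)cc3)C2=O)cc(OC)c1OC` differs from compound 2 by 4-fluorophenyl in place of 2-fluorophenyl on a double-bonded chain carbon bound to a double-bonded ring carbon. Within the data shown here, the single measured step concerns a methoxy group, not the exchange of 2-fluorophenyl for 4-fluorophenyl, so no measured step bears directly on this change, and the shared core is otherwise unchanged. The step expected is therefore a 1.0-fold lower number from compound 2 to compound 3 (0.00 log units; within the scatter), none beyond the scatter. Compound 3 is accordingly estimated at 12000 nM, expected to lie between 6000 nM and 24000 nM.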

Compound 3, half-maximal inhibitory concentration: 10700 nM
For compound 3 the middle estimate is 1.1-fold (0.05 log units) above the measured one, and the stated range covers the measured number.
By their numbers in this assay, from the lowest: compounds 3, 1 and 2 (each within the scatter of the next).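

Exchanging 2-fluorophenyl for 4-fluorophenyl on the double-bonded chain carbon bound to a double-bonded ring carbon gives a 1.1-fold lower number from compound 2 to compound 3 (0.05 log units; within the scatter) in this assay for this pair. Here the ring on that carbon changes for the first time, and shifting the fluorine between these two named forms does not separate the compounds. Nothing available explains this result.

The compounds shown leave open whether a group other than fluorine on this ring, such as an amine or a carboxylic acid, would give a step beyond the scatter.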